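The source may report more compounds than this note shows. Statements on the series, on what has been measured and on what is new or still open speak of the compounds shown alone.

Measured so far:

Compound 1 `CCOC(=O)c1ccc(/N=N/N(C)C(=O)NCCSc2ccc(O)cc2)cc1`: in a physicochemical assay for pharmacokinetics, read by HPLC, in phosphate buffer, at pH 7.4 (on this read-out lower numbers stand for a shorter-lived compound and higher numbers for a longer-lived compound), compound 1 gives > 240 h, which is a limit of the assay and not a number.
Compound 2 `CC(=O)c1ccc(/N=N/N(C)C(=O)NCCSc2ccc(O)cc2)cc1`: in this assay compound 2 gives > 240 h, again a limit and not a number.
Compound 3 `CC(=O)c1ccc(/N=N/N(C)C(=O)CCc2ccc(O)cc2)cc1`: in this assay compound 3 gives 139 h.

Within the data shown here, compound 3 thus carries the only number in the set; the other two values are limits. The difference between the core of compound 2 and the core of compound 3 is not broken down here. Compound 2 and compound 1 differ by one change, (ethoxy in place of methyl on a carbonyl carbon), and the step between them, a step that the two limits leave unreadable from compound 2 to compound 1, cannot be sized, since both of them sit at the limit of > 240 h in this assay, at which 2 of the 3 values shown sit.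

Compound 4 `CCOC(=O)c1ccc(/N=N/N(C)C(=O)CCc2ccc(O)cc2)cc1` has not yet been measured. It differs from compound 3 by ethoxy in place of methyl on a carbonyl carbon. This is the same change as the one from compound 2 to compound 1: the group that leaves, the group that enters and the place where it happens are described in the same words, and it occurs twice among the compounds shown.

Among the measured compounds shown here, for compound 4 the step from compound 3 is expected to be modest, a 1.1-fold higher number from compound 3 to compound 4 (0.03 log units; within the scatter), an expectation that rests on the value of compound 3, 139 h, as the only number available, and on the fact that the matching measured step from compound 2 to compound 1 gives no readable size. Compound 4 is therefore estimated at 150 h, with the likely range running from 70 h to 300 h.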

Compound 4, half-life: 130 h
For compound 4 the middle estimate is 1.2-fold (0.06 log units) above the measured one; measured number inside the range.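

On the core of compound 3, ethoxy in place of methyl on a carbonyl carbon gives a 1.1-fold lower number from compound 3 to compound 4 (0.03 log units; within the scatter), so in this assay this pair gives no sign that the change shifts the half-life on this core. On the core of compound 2 the same change cannot be sized, and the pair therefore offers no readable step to set beside the new one, as compound 2 and compound 1 both carry a limit of the assay and not a number: the limit of > 240 h in this assay, at which 2 of the 4 values shown sit. The transfer of this change from one core to the other is thus neither confirmed nor contradicted, and a step within the scatter on one core says nothing about the size of the step hidden behind the limits on the other.

The compounds shown leave open how the half-life in this assay would respond if a carboxylic acid, an amine or a longer chain such as propoxy took the place of ethoxy on that carbonyl carbon. Among these compounds, they also leave open which part of the difference between the core of compound 2 and the core of compound 3 goes with the values seen, as no single-place step divides that difference.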